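Notes on the step from compound 3 to compound 4

The compounds below may be only part of what the source reports. "The series", "measured", "known", "first", "only" and "open" are said of these compounds alone.

compound 1 `O=C1c2ccccc2C(=O)N1CCOC(=S)N(C(=O)c1ccc([N+](=O)[O-])cc1)c1ccc(Cl)cc1` gives > 100000 nM (a limit)
compound 2 `O=C1c2ccccc2C(=O)N1CCOC(=S)N(C(=O)c1cc(F)cc(F)c1)c1ccc(Cl)cc1` gives 59000 nM
compound 3 `O=C1c2ccccc2C(=O)N1CCOC(=S)N(C(=O)c1cc(Cl)cc(Cl)c1)c1ccc(Cl)cc1` gives 32000 nM

All three values come from an ADME assay on MT4 cells (Homo sapiens) for cytotoxicity, read by MTT assay (a higher number here means that more compound is tolerated, a lower number that less compound is tolerated), and the compounds share the core of compound 1. The entry for compound 1 is a limit and not a number. Among the compounds with values here, compound 3 stands with compound 2 as one of only two true numbers, and the gap between them is a 1.8-fold lower number from compound 2 to compound 3 (0.27 log units; within the scatter) and does not separate them.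

The unmeasured compound 4 `O=C1c2ccccc2C(=O)N1CCOC(=S)N(C(=O)c1cccc2ccccc12)c1ccc(Cl)cc1` carries naphthalen-1-yl in place of 3,5-dichlorophenyl on a carbonyl carbon and the rest of the structure stays the same.

Exchanges at this same place have given an at least 1.6-fold lower number from compound 1 to compound 2 (0.22 log units; that floor lies within the scatter) and an at least 3.1-fold lower number from compound 1 to compound 3 (0.49 log units; beyond the scatter) and both are counted from a limit, so they give floors and not sizes. Within the data shown here, none of the measured steps involves naphthalen-1-yl. Among the measured compounds shown here, the only step between two true numbers is the one to compound 3 of a 1.8-fold lower number from compound 2 to compound 3 (0.27 log units; within the scatter) and on that basis no step beyond the scatter is expected. The estimated step is a 1.1-fold higher number from compound 3 to compound 4 (0.04 log units; within the scatter) and no firm direction is expected for it. For compound 4 the estimate is 35000 nM with an expected range of 14000 nM to 90000 nM in this assay as the read-out.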

Compound 4, half-maximal cytotoxic concentration: 6000 nM
Estimate against measurement, compound 4: 5.8-fold (0.77 log units) above; measured number below the stated range.
By their numbers in this assay, from the lowest: compound 4; then compounds 3 and 2 (each within the scatter of the next). At a limit, above all of these: compound 1.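

In this assay, the exchange on a carbonyl carbon whose other neighbours are amide-type nitrogen now gives steps beyond the scatter between true numbers: a 5.3-fold lower number from compound 3 to compound 4 (0.73 log units; beyond the scatter), and a 9.8-fold lower number from compound 2 to compound 4 (0.99 log units; beyond the scatter). The earlier true numbers, for compounds 2 and 3, lie within the scatter of each other, so this position had shown no separation until naphthalen-1-yl, with its 2 six-membered aromatic rings of carbon only, took the place of the single-ring groups. Compound 1 stands at a limit and not a number, so the step to compound 4 is a floor, an at least 16-fold lower number from compound 1 to compound 4 (1.22 log units; beyond the scatter), and its full size stays unknown: the limit of > 100000 nM in this assay, at which 1 of the 4 values shown sits.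

The compounds shown do not separate the entry of the second aromatic ring from the departure of the halogens, since compound 4 differs from compounds 2 and 3 in both at once. From the compounds shown here alone, how far the lower number in this assay follows ring size or the substituent remains open, and a plain phenyl, a phenyl carrying an amine or a carboxylic acid, or a longer chain at this carbonyl carbon would each bear on that question.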